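This account rests on a few compounds, and the source may have more. Where it says the series, first, only, none or still open, it means among the compounds named here.

In a functional assay on CHO-K1 cells for antagonist activity at prostaglandin E2 receptor EP1 subtype (Homo sapiens), read by FLIPR and calcium flux (a higher number here means a weaker inhibitor, a lower number a stronger inhibitor), compound 1 `CCc1ccccc1N(CC(=O)NCc1cccc(OC)c1)S(=O)(=O)c1ccc(C)cc1` gives 138 nM, compound 2 `CCc1ccccc1N(CC(=O)NCc1ccc(Cl)cc1)S(=O)(=O)c1ccc(C)cc1` gives 11.5 nM and compound 3 `CCc1ccccc1N(CC(=O)NCc1ccccc1F)S(=O)(=O)c1ccc(C)cc1` gives 135 nM. Compound 2 has the lowest number of the three: the change from it to compound 3 gives a 12-fold higher number from compound 2 to compound 3 (1.07 log units; beyond the scatter), and the change from compound 1 to compound 2 gives a 12-fold lower number from compound 1 to compound 2 (1.08 log units; beyond the scatter), while compound 1 and compound 3 differ by a 1.0-fold lower number from compound 1 to compound 3 (0.01 log units; within the scatter). Compound 4 `CCn1nccc1N(CC(=O)NCc1ccc(Cl)cc1)S(=O)(=O)c1ccc(C)cc1` is not yet measured. It differs from compound 2 by 1-ethyl-1H-pyrazol-5-yl in place of 2-ethylphenyl on a sulfonamide nitrogen. Among the measured compounds shown here, the three measured steps all alter the group on a saturated chain carbon bound to an amide-type nitrogen, and none touches the group on the sulfonamide nitrogen, so no measured step bears directly on this change. With the shared core otherwise kept, the number for compound 4 in this assay is therefore expected to stay broadly near that of compound 2, with wide uncertainty and no clear direction. The estimate for compound 4 is 25 nM, within 6 nM to 120 nM. This estimate means an expected step of a 2.2-fold higher number from compound 2 to compound 4 (0.34 log units; beyond the scatter).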

Compound 4, inhibition constant: 72.4 nM
Estimate against measurement, compound 4: 2.9-fold (0.46 log units) below; low and high end bracket the measured number.
By their numbers in this assay, from the lowest: compound 2; then compounds 4, 3 and 1 (each within the scatter of the next).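

In this assay, among the compounds shown here, this is the first change at the group on the sulfonamide nitrogen, and replacing 2-ethylphenyl with 1-ethyl-1H-pyrazol-5-yl gives a 6.3-fold higher number from compound 2 to compound 4 (0.80 log units; beyond the scatter), so this position also affects the number and not only the group on the amide side. The swap costs some inhibition without abolishing it, since compound 4 still gives 72.4 nM with a five-membered aromatic ring carrying 2 hetero atoms. The new group has one heavy atom fewer and 2 hydrogen-bond acceptors where the old group has none, but nothing available shows which of these differences, if either, drives the step.

Still open, from the compounds shown here alone, is whether a plain phenyl, a pyridine ring or a propyl chain in place of the ethyl would recover the lost inhibition. It is also unknown whether the large gain from 4-chlorophenyl over 2-fluorophenyl holds when the 1-ethyl-1H-pyrazol-5-yl group sits on the sulfonamide nitrogen.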